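Removing the chloro from the phenyl on the triazole nitrogen

A few compounds are considered here, and "the series" means these few. Any claim that something is new, unique, unknown or untested is made for them only; others in the source may bear on it.

Of the compounds shown here, three sharing one core have been measured in a functional assay on PC-3 cells (Homo sapiens) for antiproliferative activity, read by MTT assay, with a stated time of 48 h; on this read-out higher numbers stand for weaker inhibition and lower numbers for stronger inhibition. Compound 1 `COc1cc(/C=C/C(C)=O)ccc1OCc1cn(-c2c(F)cccc2F)nn1` gives 24200 nM. Compound 2 `CCOC(=O)c1ccc(-n2cc(COc3ccc(/C=C/C(C)=O)cc3OC)nn2)cc1` gives 59200 nM. Compound 3 `COc1cc(/C=C/C(C)=O)ccc1OCc1cn(-c2ccccc2Cl)nn1` gives 48000 nM, which is the second highest of the three numbers; it sits nearest to compound 2 and furthest from compound 1, and both gaps are within the scatter. For the measured compounds named here, the one step that connects two measured compounds, a 2.0-fold higher number from compound 1 to compound 3 (0.30 log units; within the scatter), brings 2-chlorophenyl in place of 2,6-difluorophenyl on an aromatic nitrogen and lies within the scatter. Compound 2 carries a different group on that nitrogen, and its value and that of compound 3 are within the scatter of each other.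

Compound 4 `COc1cc(/C=C/C(C)=O)ccc1OCc1cn(-c2ccccc2)nn1` differs from compound 3 by hydrogen in place of chloro on an aromatic carbon, on an aromatic carbon of a six-membered aromatic ring of carbon only, ortho to a large group; cut one bond further out, the change reads 2-chlorophenyl to phenyl. Going by the values given here, the only step that bears on it, from compound 1 to compound 3, stayed within the scatter, so no step beyond the scatter is expected in either direction. The step from compound 3 to compound 4 is therefore estimated as a 1.2-fold lower number from compound 3 to compound 4 (0.08 log units; within the scatter). Compound 4 is expected to give about 40000 nM, in a range from 15000 nM to 110000 nM.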

Compound 4, half-maximal inhibitory concentration: 78600 nM
Beside the measured number, compound 4's estimate is 2.0-fold (0.29 log units) below it; measured number inside the range.
By their numbers in this assay, from the lowest: compounds 1, 3, 2 and 4 (each within the scatter of the next, the first and the last beyond it).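

In this assay, a 1.6-fold higher number from compound 3 to compound 4 (0.21 log units; within the scatter) is a step within the scatter, so taking the chloro off this aromatic carbon, ortho to a large group, has no readable effect on its own. For the compounds shown here, what compound 4 adds is the bare phenyl as a reference point on the triazole nitrogen: a 1.3-fold higher number from compound 2 to compound 4 (0.12 log units; within the scatter), hydrogen in place of ethoxycarbonyl, also stays within the scatter, whereas a 3.2-fold higher number from compound 1 to compound 4 (0.51 log units; beyond the scatter), phenyl in place of 2,6-difluorophenyl, is the first step beyond the scatter, though a modest one, so only the 2,6-difluorophenyl group separates from phenyl here. Nothing available accounts for this difference.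

The compounds shown leave open whether a single fluoro on the phenyl would be enough to give that separation from compound 4, or whether both fluoro groups of compound 1 are needed. They also leave open how this position would respond to a group of another kind on the phenyl, such as an amine or a carboxylic acid, since only chloro, fluoro and ethoxycarbonyl appear on it so far.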